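Compound 3 at the limit: trimming its alkynyl chain

The compounds below may be only part of what the source reports. "The series", "measured", "known", "first", "only" and "open" are said of these compounds alone.

Values in an ADME assay on L1210/0 cells (Mus musculus) for cytotoxicity, with a stated time of 48 h; on this read-out lower numbers stand for stronger inhibition and higher numbers for weaker inhibition:
- Compound 1 `O=c1[nH]c(=O)n([C@H]2C[C@H](O)[C@@H](CO)O2)cc1[N+](=O)[O-]`: 130 nM
- Compound 2 `N#Cc1cn([C@H]2C[C@H](O)[C@@H](CO)O2)c(=O)[nH]c1=O`: > 200000 nM
- Compound 3 `O=c1[nH]c(=O)n([C@H]2C[C@H](O)[C@@H](CO)O2)cc1C#CCCO`: > 200000 nM

Compound 3 gives only a limit and no number, > 200000 nM. Compound 2 shares that limit, so (the limit of > 200000 nM in this assay, at which 2 of the 3 values shown sit). Going by the values given here, compound 1 is the only one with a measured number.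

Compound 4 `CC#Cc1cn([C@H]2C[C@H](O)[C@@H](CO)O2)c(=O)[nH]c1=O` has the core of compound 3, and the change is hydrogen in place of hydroxymethyl on a saturated chain carbon bound to a triple-bonded carbon. In words, it is hydrogen in place of hydroxymethyl on a saturated chain carbon bound to a triple-bonded carbon, which turns 4-hydroxybut-1-yn-1-yl into prop-1-yn-1-yl.

Among the compounds with values here, no measured step alters the chain itself. The nearest evidence is an at least 1500-fold higher number from compound 1 to compound 3 (3.18 log units; beyond the scatter), and an at least 1500-fold higher number from compound 1 to compound 2 (3.18 log units; beyond the scatter) is of the same size, so the group on this aromatic carbon can matter greatly in this assay. By contrast, a step that the two limits leave unreadable from compound 2 to compound 3 gives no size to build on.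

With so little to go on, a moderately lower number than the limit of compound 3 is expected, although another limit would be no surprise. The expected step is an at least 6.6-fold lower number from compound 3 to compound 4 (0.82 log units; beyond the scatter). Compound 4 is estimated at 30000 nM, with an expected range of 1500 nM to 200000 nM.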

Compound 4, half-maximal inhibitory concentration: > 200000 nM
Compound 4 gave a limit, no number; the forecaster's own chance of this, stated with the estimate: 35%; at least 6.6-fold (0.82 log units) between middle value and limit.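

Taking the hydroxymethyl off the chain does not bring the series off the limit in this assay, so shortening 4-hydroxybut-1-yn-1-yl to prop-1-yn-1-yl produces no readable gain in this assay. With nitro on the aromatic carbon replaced by prop-1-yn-1-yl, the comparison gives an at least 1500-fold higher number from compound 1 to compound 4 (3.18 log units; beyond the scatter), a large step that shows a third group at this position standing far from the nitro compound. The steps among compound 2, compound 3 and compound 4 cannot be read, and the position now presents this picture: the limit of > 200000 nM in this assay, at which 3 of the 4 values shown sit.

Where the true values of compound 2, compound 3 and compound 4 lie remains unknown, so no order can be given among cyano, prop-1-yn-1-yl and 4-hydroxybut-1-yn-1-yl. From the compounds shown here alone, whether an amine, a carboxylic acid or a bromine atom on this aromatic carbon would come closer to compound 1 also remains open.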